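A few compounds are considered here, and "the series" means these few. Any claim that something is new, unique, unknown or untested is made for them only; others in the source may bear on it.

Measured so far:
compound 1 `Cc1cnc(Nc2ccc(S(C)(=O)=O)cc2)nc1Nc1nc2ccc(Cl)cc2s1` — 2500 nM
compound 2 `Cc1cnc(Nc2ccc(S(C)(=O)=O)cc2)nc1Nc1nc2ccccc2s1` — 760 nM
compound 3 `Cc1cnc(Nc2ccc([N+](=O)[O-])cc2)nc1Nc1nc2ccccc2s1` — 6330 nM

In a functional assay on HCT-116 cells (Homo sapiens) for antiproliferative activity, read by MTT assay, with a stated time of 48 h (a higher number here means a weaker inhibitor, a lower number a stronger inhibitor), compound 3 gives the highest number of the three: compound 1 sits nearer to it and compound 2 furthest below it, the gap being an 8.3-fold higher number from compound 2 to compound 3 (0.92 log units; beyond the scatter). Compound 4 `Cc1cnc(Nc2ccc(Cl)cc2)nc1Nc1nc2ccccc2s1` has not yet been measured. It differs from compound 3 by chloro in place of nitro on an aromatic carbon, on the six-membered aromatic ring of carbon only, para to a large group.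

Among the compounds with values here, only one measured step touches this ring: from compound 2 to compound 3 the exchange of methylsulfonyl for nitro gave an 8.3-fold higher number from compound 2 to compound 3 (0.92 log units; beyond the scatter), so the nitro group marks the weakest end seen. The step of a 3.3-fold lower number from compound 1 to compound 2 (0.52 log units; beyond the scatter) concerns a chloro on the other ring system of the shared core and bears only loosely here. Nothing measured shows chloro on this ring, so the size of its effect is open; the expectation is that leaving nitro brings the number down somewhat, toward the range of compound 1, but not as far as compound 2.

Compound 4 is therefore expected at about 3000 nM (range 1000 nM to 9000 nM), an estimated step of a 2.1-fold lower number from compound 3 to compound 4 (0.32 log units; beyond the scatter).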

Compound 4, half-maximal inhibitory concentration: > 50000 nM
Compound 4 gave a limit, no number (the forecaster's own chance of this, stated with the estimate: 5%); middle value at least 16-fold (1.22 log units) away from the limit.
By their numbers in this assay, from the lowest: compound 2; then compound 1; then compound 3. At a limit, above all of these: compound 4.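

Compound 4 stands at a limit of the assay in this assay, not at a number: the limit of > 50000 nM in this assay, at which 1 of the 4 values shown sits.

Going from nitro to chloro at this position raises the number further, an at least 7.8-fold higher number from compound 3 to compound 4 (0.89 log units; beyond the scatter), so nitro no longer marks the weak end among the groups shown here. Set against methylsulfonyl, the same chloro gives an at least 65-fold higher number from compound 2 to compound 4 (1.81 log units; beyond the scatter), a larger step at this position, para to a large group, than the removal of chloro elsewhere on the shared core, a 3.3-fold lower number from compound 1 to compound 2 (0.52 log units; beyond the scatter).

The limit leaves the true size of both new steps open, and the compounds shown give no cause for the order of methylsulfonyl, nitro and chloro. Also open, going by these compounds, is whether an amine, a carboxylic acid or a methoxy group at this position would match or improve on compound 2.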